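The compounds below may be only part of what the source reports. "The series", "measured", "known", "first", "only" and "open" are said of these compounds alone.

Measured so far:
- compound 1 `Oc1c(-c2ccccc2)cccc1C(O)(C(F)(F)F)C(F)(F)F` — 449000 nM
- compound 2 `Cc1ccc(S(=O)(=O)NNC(=O)COc2ccc3cc(C(O)(C(F)(F)F)C(F)(F)F)c(O)cc3c2)cc1` — 14900 nM

In an assay on isolated protein for inhibition of tyrosine-protein phosphatase non-receptor type 13 (Homo sapiens), read by spectrophotometry (a higher number here means a weaker inhibitor, a lower number a stronger inhibitor), compound 2 gives 14900 nM, the lower of the two numbers in hand. Compound 1 gives 449000 nM in this assay, a higher number, and the gap between the two lies beyond the scatter. The two compounds differ in more than one place, so no single step can be read from them; they only show that the larger compound 2 sits at the lower number.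

Compound 3 `O=C(COc1ccc2cc(C(O)(C(F)(F)F)C(F)(F)F)c(O)cc2c1)NC1CC1` is not yet measured in this assay. Relative to compound 2 it carries cyclopropyl in place of ((4-methylphenyl)sulfonyl)amino on an amide-type nitrogen. Within the data shown here, no measured pair in the set differs in one place, so there is no step to lean on; the expectation rests on the structural change alone. Removing the larger group and leaving a small ring on the amide-type nitrogen is expected to move the number upward, beyond the scatter, though well short of the number of compound 1.

For compound 3 in this assay the estimate is 45000 nM, with a range from 12000 nM to 150000 nM. The expected step is a 3.0-fold higher number from compound 2 to compound 3 (0.48 log units; beyond the scatter).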

Compound 3, half-maximal inhibitory concentration: > 20000 nM
Compound 3: only a limit was reported; the forecaster's own chance of this, stated with the estimate: 10%; the middle value lies beyond the limit too.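

Compound 3 is a limit, not a number, in this assay: the limit of > 20000 nM in this assay, at which 1 of the 3 values shown sits.

Among these compounds, the replacement of ((4-methylphenyl)sulfonyl)amino by cyclopropyl on an amide-type nitrogen gives the only single-place step, read as an at least 1.3-fold higher number from compound 2 to compound 3 (0.12 log units; that floor lies within the scatter). That floor does not establish a change beyond the scatter, so this position is shown only not to gain from the small ring, while the true size of the loss stays unsettled.

Open, from the compounds shown here alone, is which part of the ((4-methylphenyl)sulfonyl)amino group goes with the lower number of compound 2: the six-membered aromatic ring with its methyl, the sulfonyl, or the extra nitrogen of the (((4-methylphenyl)sulfonyl)amino)amino unit. Also open, going by these compounds, is how a plain phenyl, a primary amine, a carboxylic acid or a longer alkyl chain on the same amide-type nitrogen would read in this assay, and whether any of these would give a number rather than a limit.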